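Lengthening the Tether Toward the Amide

The source may hold more compounds than are shown below. What is called first, only, known or untested is meant among the compounds shown, and "the series" means these compounds.

Compound 2 (`CCCCc1oc2ccccc2c1C(=O)c1ccc(OCC(=O)N2CCCCC2)cc1`) carries a piperidin-1-yl amide on a short tether from the aromatic oxygen. In a functional assay on MDA-MB-231 cells (Homo sapiens) for antiproliferative activity, read by MTT assay, with a stated time of 24 h (a lower number here means a stronger inhibitor, a higher number a weaker inhibitor), compound 2 gives only a limit, > 50000 nM, rather than a number. Its two relatives share this outcome. Compound 1 (`CCCCc1oc2ccccc2c1C(=O)c1ccc(OCC(N)=O)cc1`) gives in this assay a limit of > 50000 nM. Compound 3 (`CCCCc1oc2ccccc2c1C(=O)c1ccc(OCC(=O)N[C@@H](C)c2ccccc2)cc1`) likewise gives in this assay a limit of > 50000 nM. Because every value sits at the limit of > 50000 nM in this assay, at which 3 of the 3 values shown sit, none of the steps between these compounds can be read: a step that the two limits leave unreadable from compound 1 to compound 2, a step that the two limits leave unreadable from compound 1 to compound 3 and a step that the two limits leave unreadable from compound 2 to compound 3.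

Compound 4 (`CCCCc1oc2ccccc2c1C(=O)c1ccc(OCCCC(=O)N2CCCCC2)cc1`) differs from compound 2 in one place: 2-((piperidin-1-yl)carbonyl)ethyl in place of (piperidin-1-yl)carbonyl on a saturated chain carbon bound to an oxygen on an aromatic ring. Among the compounds with values here, no measured step speaks to lengthening this chain, and the three steps that do exist are all unreadable, so neither a direction nor a size can be drawn from them. Within the data shown here, the only guidance is that all three compounds measured so far sit at the limit. Compound 4 is therefore expected to stay there as well, with the expected step of a number no higher from compound 2 to compound 4 (the limit leaves the size open) amounting to no change beyond the scatter. The estimated value for compound 4 in this assay is 50000 nM, within a range from 20000 nM to 150000 nM, and it is most likely again reported only as a limit.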

Compound 4, half-maximal inhibitory concentration: 36000 nM
The estimate for compound 4 lay 1.4-fold (0.14 log units) above the measured number; the range from low to high includes it.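

In this assay, within the data shown here, the change from ((piperidin-1-yl)carbonyl)methyl to 3-((piperidin-1-yl)carbonyl)propyl gives the first real number at this position, and it can be stated only as an at least 1.3-fold lower number from compound 2 to compound 4 (0.14 log units; that floor lies within the scatter). The other two comparisons read the same way, as an at least 1.3-fold lower number from compound 3 to compound 4 (0.14 log units; that floor lies within the scatter) and as an at least 1.3-fold lower number from compound 1 to compound 4 (0.14 log units; that floor lies within the scatter), but these also swap the group on the amide nitrogen, so they do not isolate the chain length. All three remain floors rather than sizes, and the steps among compound 1, compound 2 and compound 3 still cannot be read, because those compounds stay at a limit: the limit of > 50000 nM in this assay, at which 3 of the 4 values shown sit.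

On these data alone, how far compound 4 truly lies from compound 2 stays open, since only a number for compound 2 could show whether the step goes beyond the scatter. Also open, as far as these compounds go, is how a still longer chain at this place would read, or a carboxylic acid or a morpholin-4-yl amide in place of the piperidin-1-yl amide on the 3-carbon tether of compound 4.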